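Dropping the Amino Group from Compound 1 on Vero Cells

A few compounds are considered here, and "the series" means these few. Any claim that something is new, unique, unknown or untested is made for them only; others in the source may bear on it.

The measured compounds:
compound 1, `C/C(=N/NC(=S)N(Cc1ccccc1)Cc1ccccc1)c1ccc(N)cc1`: 161000 nM
compound 2, `C=CCN(CC=C)C(=S)N/N=C(/C)c1ccc(F)cc1`: 214000 nM
compound 3, `C=CCN(CC=C)C(=S)N/N=C\c1ccc(Cl)cc1`: 213000 nM

All three were read in an ADME assay on Vero cells (Chlorocebus sabaeus) for cytotoxicity, read by MTT assay, with a stated time of 72 h; on this read-out higher numbers stand for lower toxicity in this test and lower numbers for higher toxicity in this test. Compound 1 carries the smallest of the three numbers, but the numbers of compound 2 and compound 3 both lie within the usual scatter of it, so nothing separates the three in this assay; they sit together as a single band of low toxicity. Among the measured compounds shown here, no pair of them differs in only one place, so no single structural step between measured compounds can be read from these values.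

Compound 4, `C/C(=N/NC(=S)N(Cc1ccccc1)Cc1ccccc1)c1ccccc1`, has not yet been measured in this assay. It differs from compound 1 in one place: hydrogen in place of amino on an aromatic carbon. The place is on an aromatic carbon of a six-membered aromatic ring of carbon only, para to a large group; cut one bond further out, the change reads 4-aminophenyl to phenyl.

For the measured compounds named here, with no comparable step among the measured compounds, and all three values resting in one band, compound 4 is expected to stay in that band: the step of a 1.1-fold lower number from compound 1 to compound 4 (0.03 log units; within the scatter) is estimated to be none beyond the scatter. The estimate for compound 4 in this assay is 150000 nM, with a range from 70000 nM to 320000 nM.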

Compound 4, half-maximal cytotoxic concentration: 167000 nM
Estimate against measurement, compound 4: 1.1-fold (0.05 log units) below, within the range that was stated.
By their numbers in this assay, from the lowest: compounds 1, 4, 3 and 2 (each within the scatter of the next).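

Read in this assay the change from 4-aminophenyl to phenyl gives a 1.0-fold higher number from compound 1 to compound 4 (0.02 log units; within the scatter) and is the first step in this set that can be traced to a single place. Among the compounds shown here, on an aromatic carbon of a six-membered aromatic ring of carbon only, para to a large group, hydrogen in place of amino therefore leaves compound 1 and compound 4 indistinguishable in this test, something the earlier compounds, which differ in more than one place, could not show. No measured evidence is available to explain why the read-out holds across this change.

The compounds shown leave open whether other groups at this same place, such as a hydroxyl, a methoxy, a carboxylic acid or a longer chain like butyl, would stay in the same band of low toxicity. For the compounds shown here, they also leave open whether hydrogen in place of amino would read the same way in a compound that differs from compound 1 elsewhere, since this single pair is the only evidence for the change.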